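Methylamino variant of the furan analogue in the series

A few compounds are considered here, and "the series" means these few. Any claim that something is new, unique, unknown or untested is made for them only; others in the source may bear on it.

Compound 1 `CN(C)c1ncnc2c1c(-c1ccsc1)cn2[C@@H]1O[C@H](CO)[C@@H](O)[C@H]1O` gives 530 nM in a functional assay on K562 cells (Homo sapiens), read by MTT assay, with a stated time of 72 h; on this read-out higher numbers stand for weaker inhibition and lower numbers for stronger inhibition. For the measured compounds named here, compound 2 `CN(C)c1ncnc2c1c(-c1ccoc1)cn2[C@@H]1O[C@H](CO)[C@@H](O)[C@H]1O` gives 1540 nM in this assay, the highest of the two numbers in hand; the only measured step, a 2.9-fold higher number from compound 1 to compound 2 (0.46 log units; beyond the scatter), concerns the five-membered ring on the aromatic carbon and leaves the amine untouched. Compound 3 `CNc1ncnc2c1c(-c1ccoc1)cn2[C@@H]1O[C@H](CO)[C@@H](O)[C@H]1O` differs from compound 2 as follows: hydrogen in place of methyl on a nitrogen on an aromatic ring. Going by the values given here, no measured step bears on this position, so the size and direction of the next step in this assay cannot be read from the two values available. The working assumption is therefore no shift beyond the scatter, with a wide allowance in either direction. Compound 3 is expected to give about 1500 nM (range 500 nM to 4500 nM) in this assay. The expected step is a 1.0-fold lower number from compound 2 to compound 3 (0.01 log units; within the scatter).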

Compound 3, half-maximal inhibitory concentration: > 20000 nM
Compound 3: only a limit was reported; the forecaster's own chance of this, stated with the estimate: 5%; at least 13-fold (1.12 log units) between middle value and limit.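

Taking one methyl off the dimethylamino group moves the result in this assay much further than the exchange of the five-membered ring did: dimethylamino to methylamino gives an at least 12-fold higher number from compound 2 to compound 3 (1.11 log units; beyond the scatter), whereas furan-3-yl in place of thiophen-3-yl gave a 2.9-fold higher number from compound 1 to compound 2 (0.46 log units; beyond the scatter). For compound 3 the reading of > 20000 nM is a limit and not a number: the limit of > 20000 nM in this assay, at which 1 of the 3 values shown sits. The substituent on this nitrogen is therefore a sensitive position in the furan-3-yl pair, where keeping both methyl groups separates a measured value from a limit.

The compounds shown leave open whether the same change would have a comparable effect with the thiophen-3-yl group of compound 1. They also leave open how a longer chain such as diethylamino, a cyclic amine such as pyrrolidine, or an unsubstituted amino group would read at this position.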